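Bromine on the fused ring: expected potency gain for compound 4

The compounds below may be only part of what the source reports. "The series", "measured", "known", "first", "only" and "open" are said of these compounds alone.

Measured compounds in a functional assay on cells (Cancer cell lines, Homo sapiens) for cytotoxicity, read by sulforhodamine B assay, with a stated time of 48 h; on this read-out lower numbers stand for stronger inhibition of growth and higher numbers for weaker inhibition of growth:
compound 1 `COc1ccc(C2=NN(C3=NC(=O)/C(=C4\C(=O)Nc5ccccc54)S3)C(c3ccc(OC)cc3)C2)cc1` gives 100000 nM
compound 2 `COc1ccc(C2=NN(C3=NC(=O)/C(=C4\C(=O)Nc5ccc(Br)cc54)S3)C(c3ccc(OC)cc3)C2)cc1` gives 200 nM
compound 3 `COc1ccc(C2=NN(C3=NC(=O)/C(=C4\C(=O)Nc5ccccc54)S3)C(c3ccc(Cl)cc3)C2)cc1` gives 100000 nM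

Compound 3 stands level with compound 1 at the digits reported, and together the two have the highest numbers of the three in this assay. Within the data shown here, its only neighbour of the same value is compound 1: no change at the digits printed from compound 1 to compound 3 (within the scatter), with a chloro in place of a methoxy. The step to compound 2 is the furthest away: compound 2 carries a bromo where compound 1 carries a hydrogen, and a 500-fold lower number from compound 1 to compound 2 (2.70 log units; beyond the scatter).

Compound 4 `COc1ccc(C2=NN(C3=NC(=O)/C(=C4\C(=O)Nc5ccc(Br)cc54)S3)C(c3ccc(Cl)cc3)C2)cc1` is not yet measured. It differs from compound 3 in one place: bromo in place of hydrogen on an aromatic carbon. This is the same change that separates compound 1 from compound 2, and that step was large. Among the measured compounds shown here, since compound 1 and compound 3 give the same number in this assay, the step from compound 1 to compound 2 is the single measured step that bears on the change from compound 3 to compound 4, and a step of similar size and direction is expected: a 500-fold lower number from compound 3 to compound 4 (2.70 log units; beyond the scatter). Compound 4 is therefore estimated at 200 nM, with a range from 50 nM to 2000 nM.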

Compound 4, concentration for 50% growth inhibition: 130 nM
For compound 4 the middle estimate is 1.5-fold (0.19 log units) above the measured one; the range from low to high includes it.
By their numbers in this assay, from the lowest: compounds 4 and 2 (each within the scatter of the next); then compounds 1 and 3 (each within the scatter of the next).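

In this assay, the bromo on the six-membered aromatic ring of the fused system now shows its large effect on a second core, with a 770-fold lower number from compound 3 to compound 4 (2.89 log units; beyond the scatter); the gain is therefore not tied to the methoxy-bearing core of compound 1, and its size holds from one core to the other: the same change on two cores in this assay, a 500-fold lower number (2.70 log units; beyond the scatter) from compound 1 to compound 2 and a 770-fold lower number (2.89 log units; beyond the scatter) from compound 3 to compound 4, 1.5-fold (0.19 log units) apart, within the scatter of two such steps The swap of chloro for methoxy, so far seen only without the bromo, is now also seen with it, and a 1.5-fold lower number from compound 2 to compound 4 (0.19 log units; within the scatter) shows that it again stays within the scatter, so the earlier silence of this change was not confined to the compounds lacking the bromo: the same change on two cores in this assay, no change at the digits printed (within the scatter) from compound 1 to compound 3 and a 1.5-fold lower number (0.19 log units; within the scatter) from compound 2 to compound 4, 1.5-fold (0.19 log units) apart, within the scatter of two such steps Across these four compounds, the bromo alone separates the high numbers from the low numbers whichever of chloro or methoxy is present, and no compound shown goes against this.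

The compounds shown leave open whether this gain belongs to bromo in particular or would also come with fluoro, iodo, methyl or nitro on the same aromatic carbon. They also leave open whether a bromo on another carbon of that ring would act alike, and whether an amine or a carboxylic acid in place of the chloro would leave the number unchanged.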